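The compounds below may be only part of what the source reports. "The series", "measured", "known", "first", "only" and "open" are said of these compounds alone.

Working notes on the series in a functional assay, read by Griess assay, with a stated time of 150 min, tested at 100 ug/mL; a lower number here means a weaker effect, a higher number a stronger effect of the compound at the concentration tested.

Compound 1 `O=S(=O)(CC1=NCCO1)C1C(c2ccc(Cl)cc2)=NOC1c1ccc(Cl)cc1` is recorded in this assay as "not active" (no number reported), without a number. Compound 2 `Cc1ccc(-c2c[nH]nc2S(=O)(=O)CC2=NCCS2)cc1` is likewise recorded in this assay as "not active" (no number reported), again without a number. Within the data shown here, compound 3 `COc1ccc(C2=NOC(c3ccc(C)cc3)C2S(=O)(=O)CC2=NCCO2)cc1` is the only member of the set for which a number is given: in this assay compound 3 shows 71.3%. On the numbers shown, compound 3 therefore stands alone; the two other entries give nothing to compare it with in size.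

Compound 4 `COc1ccc(C2=NOC(c3ccc(C)cc3)C2S(=O)(=O)CC2=NCCS2)cc1` is not yet measured. It differs from compound 3 in one place: a group of 5 heavy atoms (3 carbon, 1 nitrogen, 1 sulfur; one five-membered non-aromatic ring with 2 hetero atoms) in place of a group of 5 heavy atoms (3 carbon, 1 nitrogen, 1 oxygen; one five-membered non-aromatic ring with 2 hetero atoms), on a saturated chain carbon bound to a sulfonyl sulfur. Among the measured compounds shown here, no pair of measured compounds differing in one place exists in the set, so the size of this kind of step is not known from these data. Compound 2 carries the entering group and is recorded as not active, but it also differs from compound 3 in its core, so its result says nothing firm about the step in question. The expected step from compound 3 to compound 4 is a number 9.3 percentage points lower from compound 3 to compound 4 (within the scatter), small and within the usual scatter, with a wide margin. For compound 4 the estimate in this assay is 62%, expected to fall between 35% and 82%.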

Compound 4, a percentage reported as activity, at one concentration (the size of the read-out at that concentration, not a potency): 59.6%
Compound 4: middle estimate off by 2.4 percentage points, on the high side; the range from low to high includes it.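

In this assay the series now has its first readable step: a ring with sulfur (3 carbon, 1 nitrogen, 1 sulfur) in place of a ring with oxygen (3 carbon, 1 nitrogen, 1 oxygen), on a saturated chain carbon bound to a sulfonyl sulfur, gives a number 11.7 percentage points lower from compound 3 to compound 4 (beyond the scatter). This position therefore registers the exchange of one ring atom for another, while the rest of the structure stays the same and both rings remain five-membered and non-aromatic, and compound 4 still keeps a clear read-out at 59.6%. Nothing available bears on why the sulfur ring reads lower than the oxygen ring.

Among these compounds, the single step leaves open whether the same exchange would give a similar change on the core of compound 1 or of compound 2, as neither compound has a number to compare and neither has a partner differing in one place. It also leaves open how far this position tolerates a larger departure from these two rings, such as an open-chain amine or a carboxylic acid in place of the ring.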